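The source may report more compounds than this note shows. Statements on the series, on what has been measured and on what is new or still open speak of the compounds shown alone.

In a functional assay on KB cells (Homo sapiens) for inhibition, read by MTT assay, with a stated time of 24 h, tested at 1 ug/mL (on this read-out higher numbers stand for more inhibition of growth at the one concentration tested and lower numbers for less inhibition of growth), compound 3 (`O=C(CCCCC(S)CCS)Nc1ccc(F)cc1`) gives 8.84%. This value lies within the scatter of compound 2 (`O=C(CCCCC(S)CCS)Nc1ccc(Cl)cc1`) at 13.4%, and also of compound 1 (`O=C(CCCCC1CCSS1)Nc1ccc(OC(F)(F)F)cc1`) at 1.54%, so the three numbers are not separated.

Compound 4 (`O=C(CCCCC(S)CCS)Nc1ccc(OC(F)(F)F)cc1`) keeps the core of compound 3 and alters one substituent: trifluoromethoxy in place of fluoro on an aromatic carbon. The group change is trifluoromethoxy in place of fluoro on an aromatic carbon, para to a large group.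

For the measured compounds named here, the only measured step at this place is a number 4.6 percentage points lower from compound 2 to compound 3 (within the scatter), fluoro in place of chloro, and it stays within the scatter. Going by the values given here, compound 1 carries trifluoromethoxy on a different core and reads 1.54%, but no measured step compares trifluoromethoxy with another group on the core of compound 3. No step beyond the scatter is therefore expected in this assay, and no direction is favoured.

The expected change is small, with an estimated a number 0.8 percentage points lower from compound 3 to compound 4 (within the scatter). For compound 4 the estimated value is 8%, with an expected range from 1% to 19%.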

Compound 4, percent growth inhibition at one concentration: 6%
Compound 4: the middle estimate sits 2 percentage points above what was measured; the measured number falls inside the stated range.
By their numbers in this assay, from the lowest: compounds 1, 4, 3 and 2 (each within the scatter of the next, the first and the last beyond it).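

In (this assay) trifluoromethoxy can now be read directly on the core of compound 3 (a number 2.8 percentage points lower from compound 3 to compound 4 (within the scatter)) and against chloro (a number 7.4 percentage points lower from compound 2 to compound 4 (within the scatter)), so fluoro, chloro and trifluoromethoxy on this aromatic carbon, para to a large group, are not separated, even though the entering group has 5 heavy atoms and 1 hydrogen-bond acceptor. With trifluoromethoxy held constant, the other end of the molecule also gets its first reading (a number 4.5 percentage points higher from compound 1 to compound 4 (within the scatter)): a group with no ring in place of one with a five-membered non-aromatic ring stays within the scatter. No measurement available here bears on these readings.

On these data alone, whether an amine or a carboxylic acid on this aromatic carbon would give a step beyond the scatter remains open. So does the effect of a longer chain between the amide carbonyl and the sulfur-bearing group.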